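Moving One Chlorine Around the Ring of Compound 2

The compounds below may be only part of what the source reports. "The series", "measured", "known", "first", "only" and "open" are said of these compounds alone.

Going by the values given here, in a functional assay on HeLa cells (Homo sapiens) for cytotoxicity, read by MTT assay, with a stated time of 48 h, tested at 25 uM (on this read-out lower numbers stand for a weaker effect and higher numbers for a stronger effect at the one concentration tested), compound 2 `CS(=O)(=O)c1ccc(Cc2n[nH]c(=S)n2/N=C/c2ccccc2Cl)cc1` gives 36.3%, the higher of the two numbers measured so far. Compound 1 `CS(=O)(=O)c1ccc(Cc2n[nH]c(=S)n2/N=C/c2cccnc2)cc1` gives 19.4%, and the change between them was a number 16.9 percentage points higher from compound 1 to compound 2 (beyond the scatter). Compound 3 `CS(=O)(=O)c1ccc(Cc2n[nH]c(=S)n2/N=C/c2ccc(Cl)cc2)cc1` differs from compound 2 by 4-chlorophenyl in place of 2-chlorophenyl on a carbon with a double bond to nitrogen. Among the compounds with values here, no measured step shifts a chlorine within the same ring; the only step known concerns a different exchange, so it offers little guidance, and no change beyond the scatter is expected in this assay. Compound 3 is therefore estimated at 32%, within 15% to 50%, an expected step of a number 4.3 percentage points lower from compound 2 to compound 3 (within the scatter).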

Compound 3, a percentage reported as activity, at one concentration (the size of the read-out at that concentration, not a potency): 47.5%
Compound 3: middle estimate off by 15.5 percentage points, on the low side; the range from low to high includes it.
By their numbers in this assay, from the lowest: compound 1; then compound 2; then compound 3.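

With the same atoms joined differently, this assay still records a number 11.2 percentage points higher from compound 2 to compound 3 (beyond the scatter) for this one move of the chlorine, so where the chlorine sits on this ring matters, not only that it is present. Against pyridin-3-yl, 4-chlorophenyl gives a number 28.1 percentage points higher from compound 1 to compound 3 (beyond the scatter) on the same carbon. No available evidence explains why the position of the chlorine matters.

Still open, on these data alone, is how 3-chlorophenyl would compare. It is also unknown whether 4-methoxyphenyl or 4-aminophenyl would match the chlorine at this place.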